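The compounds below may be only part of what the source reports. "The series", "measured", "known", "first", "only" and "open" are said of these compounds alone.

Working notes on the series. Of the compounds shown here, two of the shared core have been measured in a functional assay on the whole organism with Mus musculus as the target; a higher number here means that more compound is needed for the effect, a lower number that less compound is needed. Compound 1 `CC1(C)OC(C)(C)c2nc(-c3ccccc3)nnc21` gives 167 mg/kg. Within the data shown here, compound 2 `CC1(C)OC(C)(C)c2nc(-c3cccnc3)nnc21` gives 28.1 mg/kg, the lowest of the two numbers, with compound 1 as its only neighbour. Among the measured compounds shown here, the one measured step, a 5.9-fold lower number from compound 1 to compound 2 (0.77 log units; beyond the scatter), is beyond the scatter. Compound 3 `CC1(C)OC(C)(C)c2nc(-c3ccncc3)nnc21` differs from compound 2 only in the aryl group: pyridin-4-yl in place of pyridin-3-yl on an aromatic carbon. For the measured compounds named here, no measured step exchanges one pyridyl ring for another; the step from compound 1 to compound 2 introduced the ring nitrogen and is the only one that bears on this change, so the position of that nitrogen is untested. The expectation is therefore a number close to that of compound 2, with no step beyond the scatter. The estimate for compound 3 in this assay is 30 mg/kg, within 12 mg/kg to 75 mg/kg. This corresponds to an expected step of a 1.1-fold higher number from compound 2 to compound 3 (0.03 log units; within the scatter).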

Compound 3, dose for half-maximal effect: 56.2 mg/kg
The estimate for compound 3 lay 1.9-fold (0.27 log units) below the measured number; the range from low to high includes it.
By their numbers in this assay, from the lowest: compounds 2 and 3 (each within the scatter of the next); then compound 1.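

In this assay, moving the ring nitrogen from pyridin-3-yl to pyridin-4-yl at this aromatic carbon gives a 2.0-fold higher number from compound 2 to compound 3 (0.30 log units; within the scatter) and so does not separate the two pyridyl groups. Pyridin-4-yl in place of phenyl gives a 3.0-fold lower number from compound 1 to compound 3 (0.47 log units; beyond the scatter) and so shows that the step away from phenyl, beyond the scatter, is not confined to pyridin-3-yl. Nothing measured here explains the difference from phenyl or bears on the position of the ring nitrogen.

The compounds shown leave open how pyridin-2-yl, or a pyridine ring carrying an amine or a carboxylic acid, would read at this position. They also leave open whether the pyridyl gain over phenyl persists with a longer chain in place of the methyl groups of the shared core.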